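A few compounds are considered here, and "the series" means these few. Any claim that something is new, unique, unknown or untested is made for them only; others in the source may bear on it.

In an assay on CHO cells for displacement of a labelled ligand from adenosine receptor A1 (Homo sapiens), read by scintillation counting, with a stated time of 120 min, tested at 10 uM (a higher number here means more inhibition at the concentration tested (going by the name of the read-out), a lower number less inhibition), the measured compounds are:

Compound 1 `Nc1scc(CN2CCN(c3ccc(Cl)cc3F)CC2)c1C(=O)c1ccc(Cl)cc1`: 0%
Compound 2 `Nc1scc(CN2CCN(c3ccccc3C(F)(F)F)CC2)c1C(=O)c1ccc(Cl)cc1`: 0%
Compound 3 `Nc1scc(CN2CCN(c3c(F)cccc3F)CC2)c1C(=O)c1cccc(C(F)(F)F)c1`: 0%

Compound 2 stands level with compounds 1 and 3 at the digits shown. Its nearest neighbour is compound 1 and its furthest is compound 3, and neither gap reaches beyond the scatter of this measurement. Going by the values given here, only one measured step changes a single place: no change at the digits printed from compound 1 to compound 2 (within the scatter), a swap of the group on the amine nitrogen in a ring of the shared core, which left the read-out flat.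

Compound 4 `Nc1scc(CN2CCN(c3cccc(F)c3F)CC2)c1C(=O)c1ccc(Cl)cc1` has not yet been measured in this assay. It differs from compound 2 in one place: 2,3-difluorophenyl in place of 2-(trifluoromethyl)phenyl on an amine nitrogen in a ring. The measured step bears directly on this change, as it alters the same amine nitrogen in a ring, and it was flat. Compound 2 gives 0%, and compound 3, which also carries a difluorophenyl on that nitrogen, gives 0%. Compound 4 is therefore expected to show no change at the digits printed from compound 2 to compound 4 (within the scatter), no step beyond the scatter. The estimate for compound 4 is 0%, with a range from -8% to 12%.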

Compound 4, a percentage reported as inhibition, at one concentration (the size of the read-out at that concentration, not a potency): 0%
Beside the measured number, compound 4's estimate shows no gap at the digits printed; the range from low to high includes it.
By their numbers in this assay, from the lowest: compounds 1, 2, 3 and 4 (each within the scatter of the next).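

In this assay, the read-out shows no change at the digits printed from compound 2 to compound 4 (within the scatter) and no change at the digits printed from compound 1 to compound 4 (within the scatter), so the flat result on the amine nitrogen in a ring now extends to a third substitution pattern on the phenyl group. Taking out 2-(trifluoromethyl)phenyl, with 10 heavy atoms, and putting in 2,3-difluorophenyl, with 8, did not move the value, though a read-out with no inhibition in any of these compounds cannot rank the groups against one another. No supporting data bear on why the value stays flat.

As far as these compounds go, what remains open is whether any group on this nitrogen gives measurable inhibition, such as a pyridine ring, a benzyl group or a simple alkyl chain in place of the phenyl. From the compounds shown here alone, it is also open whether an amine or a carboxylic acid on that phenyl ring would change the read-out.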